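The source may report more compounds than this note shows. Statements on the series, on what has been measured and on what is new or still open speak of the compounds shown alone.

Working notes on the series.

Compound 1 `C=C(Br)C(=O)Nc1ccc(C(=O)/C=C/c2cc(OC)cc(OC)c2)cc1` and compound 2 `C=C(Br)C(=O)Nc1ccc(C(=O)/C=C/c2cc(OC)c(OC)c(OC)c2)cc1` share one core. Compound 2 carries, relative to compound 1, the change (methoxy in place of hydrogen on an aromatic carbon). In a functional assay on L1210 cells (Mus musculus) for antiproliferative activity, with a stated time of 48 h (on this read-out lower numbers stand for stronger inhibition and higher numbers for weaker inhibition), compound 1 gives 2700 nM, and in this assay compound 2 gives 1500 nM; the step is a 1.8-fold lower number from compound 1 to compound 2 (0.26 log units; within the scatter). On its own, this single pair shows no clear gain from the added methoxy.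

Compound 3 `COc1ccc(/C=C/C(=O)c2ccc(N)cc2)c(OC)c1` belongs to a second core; the difference between the core of compound 1 and the core of compound 3 is not broken down here. In this assay compound 3 gives 34000 nM, the highest number of the three measured, and its gaps to compound 1 and to compound 2 both lie beyond the scatter.

Compound 4 `COc1ccc(/C=C/C(=O)c2ccc(N)cc2)c(OC)c1OC` has not yet been measured. It differs from compound 3 by methoxy in place of hydrogen on an aromatic carbon. Going by the values given here, this is the same kind of change as the one from compound 1 to compound 2, but not the same: in compound 2 the entering methoxy is para to a large group, whereas in compound 4 it is meta to a large group. Among the compounds with values here, the only precedent for a methoxy entering in place of hydrogen here is the pair of compound 1 and compound 2, and its step lies within the scatter. Within the data shown here, the step from compound 3 to compound 4 in this assay is therefore expected to be a 1.7-fold lower number from compound 3 to compound 4 (0.23 log units; within the scatter), small, because a 1.8-fold lower number from compound 1 to compound 2 (0.26 log units; within the scatter) is the only guide and the second core adds its own uncertainty. Compound 4 is estimated at 20000 nM, with a likely range from 8000 nM to 50000 nM.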

Compound 4, half-maximal inhibitory concentration: 25000 nM
For compound 4 the middle estimate is 1.3-fold (0.10 log units) below the measured one, and the stated range covers the measured number.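

In this assay the methoxy entering on the core of compound 3 gives a 1.4-fold lower number from compound 3 to compound 4 (0.13 log units; within the scatter), and set beside the earlier case, the change carries from one core to the other with no difference in size that can be told apart: the same change on two cores in this assay, a 1.8-fold lower number (0.26 log units; within the scatter) from compound 1 to compound 2 and a 1.4-fold lower number (0.13 log units; within the scatter) from compound 3 to compound 4, 1.3-fold (0.12 log units) apart, within the scatter of two such steps. Since neither step lies beyond the scatter, the two cores agree only in showing no clear effect of this change, and this agreement does not show a gain in activity that transfers between cores. The comparison also rests on just two pairs and the place is not the same in both, with the methoxy in compound 4 standing meta to a large group and ortho to two methoxy groups, so an influence of place cannot be separated from an influence of core.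

The compounds shown leave open whether another group entering in place of the same hydrogen, such as a hydroxyl, a fluorine or an ethoxy, would give a step beyond the scatter on either core. Also open, going by these compounds, is whether an amine or a carboxylic acid there would behave alike on the two cores.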